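The compounds below may be only part of what the source reports. "The series", "measured", "known", "first", "only" and "open" are said of these compounds alone.

Measured compounds:
Compound 1 `CC(=O)/N=C1\NC2(CCCCO2)CCS1`: in a functional assay on the whole organism (strain CF-1) with Mus musculus as the target, in the writhing test, with a stated time of 15 min (a higher number here means that more compound is needed for the effect, a lower number that less compound is needed), compound 1 gives 3.1 mg/kg.
Compound 2 `c1ccc(/N=C2\NC3(CCCCO3)CCS2)cc1`: for compound 2 only a limit is recorded, > 200 mg/kg.
Compound 3 `COc1ccc(C(=O)/N=C2\NC3(CCCCO3)CCS2)cc1OC`: in this assay compound 3 gives 200 mg/kg.

Compound 1 stands lowest of the two numbers in this assay. Its nearest neighbour is compound 3, whose number lies far above that of compound 1, beyond the scatter. Compound 2 sits at the limit of > 200 mg/kg in this assay, at which 1 of the 3 values shown sits.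

Compound 4 `O=C(/N=C1\NC2(CCCCO2)CCS1)c1ccccc1O` is not yet measured. The change from compound 1 is 2-hydroxyphenyl in place of methyl on a carbonyl carbon. Among the measured compounds shown here, the one measured step that touches the same position, an at least 64-fold higher number from compound 1 to compound 2 (1.80 log units; beyond the scatter), is large; it replaces the whole acetyl with an aryl group, not only the methyl. Compound 3, which keeps the carbonyl and carries an aryl group on it, also gives a number far above compound 1. Both point towards a higher number for compound 4, in the same direction and of a sizeable magnitude, with uncertainty as to how far.

Compound 4 is therefore expected near 60 mg/kg, within 15 mg/kg to 200 mg/kg. That estimate means a step of a 19-fold higher number from compound 1 to compound 4 (1.29 log units; beyond the scatter).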

Compound 4, dose for half-maximal effect: > 200 mg/kg
Compound 4: only a limit was reported (the forecaster's own chance of this, stated with the estimate: 25%); middle value at least 3.3-fold (0.52 log units) from the limit.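

In this assay, keeping the carbonyl and changing only the group on it is enough for a large loss: an at least 64-fold higher number from compound 1 to compound 4 (1.80 log units; beyond the scatter). The step to compound 2 replaced the whole acetyl, so it could not separate the carbonyl from the methyl, whereas compound 4 shows that the high number does not depend on losing the carbonyl. The result for compound 4 is a limit, so the full size of this step stays unread: the limit of > 200 mg/kg in this assay, at which 2 of the 4 values shown sit.

Nothing shown lies between methyl and an aryl group on the carbonyl carbon, so it remains open whether an ethyl group, a longer chain or an aminomethyl group would keep the low number of compound 1. The part played by the hydroxyl of 2-hydroxyphenyl also remains open, as no unsubstituted phenyl on the carbonyl carbon stands among these compounds.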